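The source may hold more compounds than are shown below. What is called first, only, known or untested is meant among the compounds shown, and "the series" means these compounds.

Measured compounds in a functional assay on CHO cells for agonist activity at Free fatty acid receptor 1 (Homo sapiens), read by a luciferase reporter, with a stated time of 24 h; on this read-out lower numbers stand for an effect already at smaller amounts and higher numbers for an effect only at larger amounts of compound:
compound 1 `Cn1c(-c2ccccc2Br)cc2cc(CCC(=O)O)ccc21`: > 10000 nM, a limit of the assay.
compound 2 `Cc1ncccc1-c1cc2cc(CCC(=O)O)ccc2[nH]1`: > 25 nM, also a limit.
compound 3 `Cn1c(-c2cccc(Cl)c2)cc2cc(CCC(=O)O)ccc21`: > 10000 nM, again a limit.

Compound 3 thus sits at the limit of > 10000 nM in this assay, at which 2 of the 3 values shown sit; no number is known for it. Compound 4 `Cn1c(-c2ccc(Cl)cc2)cc2cc(CCC(=O)O)ccc21` differs from it by 4-chlorophenyl in place of 3-chlorophenyl on an aromatic carbon. Among the compounds with values here, the only measured step that touches this part of the series is a step that the two limits leave unreadable from compound 1 to compound 3, and it runs between two limits, so its size cannot be read. No readable step bears on the change to compound 4, and its direction is open. With both neighbours of the methylated core at the same limit, compound 4 is expected to give 12000 nM (range 2000 nM to 60000 nM), most likely reported again as a limit, which would mean an estimated step that the limit leaves unreadable from compound 3 to compound 4.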

Compound 4, half-maximal effective concentration: > 10000 nM
Compound 4 gave a limit, no number (the forecaster's own chance of this, stated with the estimate: 65%); the middle value is on the limit's open side.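

No step among compound 1, compound 3 and compound 4 can be read, as all three values are limits and not numbers: the limit of > 10000 nM in this assay, at which 3 of the 4 values shown sit.

As far as these compounds go, whether 2-bromophenyl, 3-chlorophenyl and 4-chlorophenyl differ at all on the shared core stays open.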